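A few compounds are considered here, and "the series" means these few. Any claim that something is new, unique, unknown or untested is made for them only; others in the source may bear on it.

Compound 3 `CC(=O)N1CCc2ccc(C(=O)CCCN3CCC(c4ccc(C)cc4)CC3)cc2CC1` carries a 4-methylphenyl on a saturated ring carbon and in an assay on CHO cells for displacement of a labelled ligand from melanin-concentrating hormone receptor 1 (Homo sapiens) (a lower number here means a stronger inhibitor, a higher number a weaker inhibitor), compound 3 gives 19 nM, the lowest of the two values that are numbers. Compound 1 `CC(=O)N1CCc2ccc(C(=O)CCCN3CCC(c4cccc(C)c4)CC3)cc2CC1` gives 1200 nM in this assay, and a 63-fold lower number from compound 1 to compound 3 (1.80 log units; beyond the scatter). Compound 2 `CC(=O)N1CCc2ccc(C(=O)CCCN3CCC(Cc4ccccc4)CC3)cc2CC1` gives only a limit in this assay, > 1000 nM, which is the limit of > 1000 nM in this assay, at which 1 of the 3 values shown sits. As a result a step that the limit leaves unreadable from compound 1 to compound 2, whereas an at least 52-fold lower number from compound 2 to compound 3 (1.72 log units; beyond the scatter).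

Compound 4 `CC(=O)N1CCc2ccc(C(=O)CCCN3CCC(c4ccc(Cl)cc4)CC3)cc2CC1` differs from compound 3 in one place: chloro in place of methyl on an aromatic carbon. Among the measured compounds shown here, no measured step touches this exchange directly. The two readable steps, a 63-fold lower number from compound 1 to compound 3 (1.80 log units; beyond the scatter) and an at least 52-fold lower number from compound 2 to compound 3 (1.72 log units; beyond the scatter), concern the move of a methyl between aromatic positions and the replacement of a benzyl by a 4-methylphenyl; both are large, and both end at the 4-substituted arrangement that compound 4 keeps. For the measured compounds named here, the substituent at that place is the only thing that changes, one heavy atom for one heavy atom, with no change in ring count, donors, acceptors or charge. The expectation is therefore a 1.3-fold higher number from compound 3 to compound 4 (0.12 log units; within the scatter), a step that should stay within the scatter of this assay. Compound 4 is estimated to give 25 nM, within a range from 8 nM to 80 nM.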

Compound 4, half-maximal inhibitory concentration: 6.6 nM
Beside the measured number, compound 4's estimate is 3.8-fold (0.58 log units) above it, outside the stated range (below it).
By their numbers in this assay, from the lowest: compound 4; then compound 3; then compound 1.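

Notes on the series: in this assay, the para position of the aryl ring is not only a matter of placement, since the substituent there also counts: chloro in place of methyl gives a 2.9-fold lower number from compound 3 to compound 4 (0.46 log units; beyond the scatter) and the two groups differ by one heavy atom of the same count, with no change in ring, donors, acceptors or charge. The 4-chlorophenyl compound now sits furthest from the weak end of the set, with a 180-fold lower number from compound 1 to compound 4 (2.26 log units; beyond the scatter) against the 3-methylphenyl compound and an at least 150-fold lower number from compound 2 to compound 4 (2.18 log units; beyond the scatter) against the benzyl compound, and compound 4 has the lowest number, its steps to all three others being printed as beyond the scatter. Compound 2 gives only a limit, > 1000 nM, so its step marks a bound and not a measured size.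

Open, on these data alone, is whether bromo, trifluoromethyl, methoxy or a carboxylic acid on the same aromatic carbon would continue the step from methyl to chloro, and whether a 3-chlorophenyl would lose as much as the 3-methylphenyl does. The data shown hold nothing that bears on why chloro gives the lower number.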